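Chloro to bromo on the 4-chlorophenyl group

The source may report more compounds than this note shows. Statements on the series, on what has been measured and on what is new or still open speak of the compounds shown alone.

In a functional assay on SK-MEL-28 cells (Homo sapiens) for cytotoxicity, read by CCK-8 assay, with a stated time of 24 h (a higher number here means a weaker inhibitor, a lower number a stronger inhibitor), compound 1 `COc1ccccc1Oc1c(N)nc(-c2ccc(F)cc2)nc1Cl` gives 31900 nM and compound 2 `COc1ccccc1Oc1c(N)nc(-c2ccc(Cl)cc2)nc1Cl` gives 120 nM as its half-maximal inhibitory concentration. Within the data shown here, compound 2 therefore holds the lower of the two numbers measured so far, and compound 1 is its only neighbour.

The next compound is compound 3 `COc1ccccc1Oc1c(N)nc(-c2ccc(Br)cc2)nc1Cl`, with bromo in place of chloro on an aromatic carbon of a six-membered aromatic ring of carbon only, para to a large group. The counted change is bromo in place of chloro on an aromatic carbon and nothing else in the structure differs.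

Among the measured compounds shown here, one measured step bears on this change, the swap of fluoro for chloro on an aromatic carbon. It is large, a 270-fold lower number from compound 1 to compound 2 (2.42 log units; beyond the scatter) and it lies well beyond the scatter. A single step sets no trend across the halogens, so it gives no direction for the next swap, but it does show that one halogen swap can move this number far. No step beyond the scatter is expected, and the estimated step is a 1.3-fold higher number from compound 2 to compound 3 (0.10 log units; within the scatter) with a wide margin. Compound 3 is estimated at 150 nM with an expected range of 25 nM to 2000 nM in this assay for this series.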

Compound 3, half-maximal inhibitory concentration: 14 nM
The estimate for compound 3 lay 11-fold (1.03 log units) above the measured number; measured number outside the range, below it.
By their numbers in this assay, from the lowest: compound 3; then compound 2; then compound 1.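

In this assay, the number keeps falling past chloro at this position: bromo in place of chloro on the 4-chlorophenyl group gives a further drop (an 8.6-fold lower number from compound 2 to compound 3 (0.93 log units; beyond the scatter)), so compound 2 does not mark the low end of the halogen series. With fluoro included, the three halogens now fall in a single order, with fluoro highest, chloro in the middle and bromo lowest; none of the three compounds goes against that order, the full span is large (a 2300-fold lower number from compound 1 to compound 3 (3.36 log units; beyond the scatter)), and compound 3 is the strongest inhibitor of the three. No measurement at hand explains this order, so the three numbers describe it without accounting for it.

Three halogens at one position cannot show whether the order extends to iodo, or whether a non-halogen such as a methyl group, an amine or a nitrile at the same place could match the number of compound 3. Also open, from the compounds shown here alone, is whether the same order would hold with the chloro, the amine or the 2-methoxyphenoxy group on the shared core replaced, since all three compounds carry these unchanged.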